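Swapping a spiro bicycle for pyrrolidine: the lipophilicity question

The source may report more compounds than this note shows. Statements on the series, on what has been measured and on what is new or still open speak of the compounds shown alone.

Measured so far:
Compound 1, `CN1CC2(C1)CN(c1ccc(OCc3ccccc3)c(C(=O)Nc3ccnnc3)c1)C2`, in a physicochemical assay for lipophilicity, at pH 7.4 (a higher number here means a more lipophilic compound, a lower number a more polar compound), compound 1 gives 2.
Compound 2, `O=C(Nc1cccc(Cl)c1)c1cc(C(F)(F)F)ccc1OCc1ccc(F)cc1`, in this assay compound 2 gives 8.7.

Among the measured compounds shown here, only two compounds have been measured, and they do not differ in a single place, so no step between them can be traced. What the two numbers show is plain: compound 1 stands lowest of the two, and compound 2 lies well above it, a gap far beyond the scatter.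

Compound 3, `O=C(Nc1ccnnc1)c1cc(N2CCCC2)ccc1OCc1ccccc1`, has not yet been measured. It differs from compound 1 in one place: a group of 5 heavy atoms (4 carbon, 1 nitrogen; one five-membered non-aromatic ring with 1 hetero atom) in place of a group of 8 heavy atoms (6 carbon, 2 nitrogen; 2 four-membered non-aromatic rings with 1 hetero atom each), on an aromatic carbon.

For the measured compounds named here, with no measured step of this kind to lean on, the expectation rests on where compound 1 sits at 2 and on the nature of the exchange. The account estimates a clear upward step in this assay, a number 1.80 log units higher from compound 1 to compound 3 (beyond the scatter), beyond the scatter. For compound 3 the estimate is 3.8, with a range from 3 to 4.6.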

Compound 3, distribution coefficient: 6.1
For compound 3 the middle estimate is 2.30 log units below the measured one, outside the stated range (above it).
By their numbers in this assay, from the lowest: compound 1; then compound 3; then compound 2.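

In this assay, among the compounds shown here, replacing the group with 2 four-membered non-aromatic rings by pyrrolidin-1-yl, on the aromatic carbon para to the benzyloxy group and meta to the (pyridazin-4-yl)carbamoyl group, gives a number 4.10 log units higher from compound 1 to compound 3 (beyond the scatter) and provides the first step that can be traced here. It shows that a change at this one place, with the rest of the core of compound 1 unchanged, can move the read-out by a large amount, which the earlier pair, differing in more than one place, could not show. No measurement shown here bears on what lies behind the size of this step.

For the compounds shown here, the single step changes several things at once: the heavy-atom count, the ring sizes, the number of rings and the number of nitrogens in the group, so it cannot separate their contributions. From the compounds shown here alone, whether a morpholine ring, a piperidine ring or an open-chain dimethylamino group at the same place would lie nearer compound 1 or compound 3 remains open, as does whether the step would hold on a different core.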